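3-Chlorophenyl to 3-Methoxyphenyl: Working Notes on the Series

The compounds below may be only part of what the source reports. "The series", "measured", "known", "first", "only" and "open" are said of these compounds alone.

In a functional assay on SMMC-7721 cells (Homo sapiens) for inhibition, read by MTT assay, with a stated time of 48 h (on this read-out lower numbers stand for stronger inhibition and higher numbers for weaker inhibition), compound 1 (`Nc1n[nH]c2cccc(-c3cccc(NC(=O)Nc4ccccc4F)c3)c12`) gives 2360 nM and compound 2 (`Nc1n[nH]c2cccc(-c3cccc(NC(=O)Nc4cccc(Cl)c4)c3)c12`) gives 1830 nM. These two values lie within the scatter of each other, so compound 2 stands level with compound 1 on the numbers available. Compound 3 (`COc1cccc(NC(=O)Nc2cccc(-c3cccc4[nH]nc(N)c34)c2)c1`) has methoxy in place of chloro on an aromatic carbon, meta to a large group: methoxy in place of chloro on an aromatic carbon. Within the data shown here, no measured step covers a methoxy group. Among the measured compounds shown here, the nearest evidence is the single step on the same aryl group, a 1.3-fold lower number from compound 1 to compound 2 (0.11 log units; within the scatter), which exchanges 2-fluorophenyl for 3-chlorophenyl and stays within the scatter. On that slim basis, no change beyond the scatter is expected in this assay, and no direction is favoured. The estimated step is a 1.1-fold higher number from compound 2 to compound 3 (0.04 log units; within the scatter). For compound 3 the expected value is 2000 nM, with an estimated range of 900 nM to 4500 nM.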

Compound 3, half-maximal inhibitory concentration: 2860 nM
Compound 3: the middle estimate sits 1.4-fold (0.16 log units) below what was measured; the measured number falls inside the stated range.
By their numbers in this assay, from the lowest: compounds 2, 1 and 3 (each within the scatter of the next).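

In this assay, the step for methoxy in place of chloro on an aromatic carbon reads a 1.6-fold higher number from compound 2 to compound 3 (0.19 log units; within the scatter) and the step for the exchange of the whole aryl group reads a 1.2-fold higher number from compound 1 to compound 3 (0.08 log units; within the scatter) in the same read-out. This position therefore accepts a group with two heavy atoms and a hydrogen-bond acceptor in place of chloro with no step beyond the scatter, whereas compound 1 and compound 2 covered only halogen-bearing aryl groups. No available measurement bears on what lies behind this result.

As far as these compounds go, whether any group at this position gives a step beyond the scatter stays open, for example an amine, a carboxylic acid or a longer chain such as ethoxy. The compounds shown also leave open how methoxy behaves elsewhere on this aryl ring, and whether any of these changes would read differently outside this cell line.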